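Swapping the bromophenyl for a trifluoromethylphenyl arm

The source may report more compounds than this note shows. Statements on the series, on what has been measured and on what is new or still open speak of the compounds shown alone.

Of the compounds shown here, two of the shared core have been tested in a functional assay on U-937 cells (Homo sapiens) for cytotoxicity, read by CCK-8 assay, with a stated time of 72 h; on this read-out lower numbers stand for stronger inhibition and higher numbers for weaker inhibition. Compound 1, `C=CCn1c(=O)/c(=C\c2ccc(F)c(Br)c2)[nH]c(=O)/c1=C\c1ccccc1OC`, was reported in this assay as "not active" (no number reported), with no number attached. For the measured compounds named here, compound 2, `C=CCn1c(=O)/c(=C\c2cccc(Br)c2)[nH]c(=O)/c1=C\c1ccccc1OC`, is the only compound with a number: in this assay compound 2 gives 1100 nM, so it stands alone as the reference point. Compound 3, `C=CCn1c(=O)/c(=C\c2ccccc2C(F)(F)F)[nH]c(=O)/c1=C\c1ccccc1OC`, has not yet been measured in this assay. It differs from compound 2 by 2-(trifluoromethyl)phenyl in place of 3-bromophenyl on a double-bonded chain carbon bound to an aromatic carbon. Going by the values given here, no step between measured compounds exists to show what such a change does, and the outcome of compound 1 shows that alterations on this ring can remove measurable activity altogether. The author therefore expects a step from compound 2 to compound 3 of a 3.2-fold higher number from compound 2 to compound 3 (0.50 log units; beyond the scatter), toward weaker inhibition and beyond the scatter. Compound 3 is estimated at 3500 nM, within a range from 900 nM to 15000 nM.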

Compound 3, half-maximal inhibitory concentration: 1500 nM
Compound 3: middle estimate off by 2.3-fold (0.37 log units), on the high side; the range from low to high includes it.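

Read in this assay, the change gives a 1.4-fold higher number from compound 2 to compound 3 (0.13 log units; within the scatter) and so lies within the scatter. For the compounds shown here, this is the first reading of a change at this place on a double-bonded chain carbon bound to an aromatic carbon, and it shows that a measurable number survives the exchange of one aryl arm for a quite different one, which the "not active" outcome of compound 1 alone could not show. Nothing available here bears on why the two arms read within the scatter of each other.

The compounds shown leave open what the trifluoromethyl group and its place on the ring each contribute, for both the group and its place differ in this one step. They also leave open how this arm would read in the same assay with an amine or a carboxylic acid on the ring.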